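Swapping the Dimethoxyphenyl for a tert-Butylphenyl on Sulfur

A few compounds are considered here, and "the series" means these few. Any claim that something is new, unique, unknown or untested is made for them only; others in the source may bear on it.

Measured in a functional assay on HCT-116 cells (Homo sapiens) for inhibition, read by CCK-8 assay, with a stated time of 72 h, tested at 8 uM; on this read-out lower numbers stand for less inhibition of growth and higher numbers for more inhibition of growth at the one concentration tested:
- compound 1 `COc1ccc(SCc2ccc(/C=C/C(=O)Nc3ccccc3N)cc2)cc1OC` gives 49.5%
- compound 2 `Nc1ccccc1NC(=O)c1ccc(CSc2ccc(Br)cc2)cc1` gives 67.7%
- compound 3 `COc1ccc(SCc2ccc(C(=O)Nc3ccccc3N)cc2)cc1` gives 90.1%

Compound 1 stands lowest of the three numbers. Compound 2 sits beyond the scatter above it, and compound 3 further still. Among the compounds with values here, the one step between compounds that differ in a single place is a number 22.4 percentage points higher from compound 2 to compound 3 (beyond the scatter), a modest gain for a methoxy in place of a bromo on an aromatic carbon.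

Compound 4 `CC(C)(C)c1ccc(SCc2ccc(/C=C/C(=O)Nc3ccccc3N)cc2)cc1` differs from compound 1 in one place: 4-(tert-butyl)phenyl in place of 3,4-dimethoxyphenyl on a sulfur. Within the data shown here, no measured step touches this change. The step from compound 2 to compound 3 concerns a different pair of groups on a ring that compound 4 keeps unchanged, so it offers no direct guide, and compound 1 is the only one of the three with the same shared core as compound 4. With nothing to lean on, compound 4 is expected to land near compound 1, with a broad range. The estimate for compound 4 is 50%, between 25% and 75%, which means an expected step of a number 0.5 percentage points higher from compound 1 to compound 4 (within the scatter), not beyond the scatter.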

Compound 4, percent growth inhibition at one concentration: 39%
Compound 4: middle estimate off by 11 percentage points, on the high side; the measured number falls inside the stated range.
By their numbers in this assay, from the lowest: compound 4; then compound 1; then compound 2; then compound 3.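

In this assay, within the data shown here, this is the first evidence that the group on the sulfur affects the result: 4-(tert-butyl)phenyl in place of 3,4-dimethoxyphenyl gives a number 10.5 percentage points lower from compound 1 to compound 4 (beyond the scatter). The two groups both have 10 heavy atoms and one six-membered aromatic ring, so the step occurs without a change in heavy-atom count, while the hydrogen-bond acceptors go from 2 to 0. Nothing available explains the drop.

This single swap removes both oxygen-bearing groups and adds the tert-butyl group at once, so the compounds shown cannot separate the effect of losing one from the effect of gaining the other. From the compounds shown here alone, it also remains open how an amine or a carboxylic acid on this ring would compare on the shared core.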